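Benzofuranyl in place of furanyl on the diamino nucleoside

The source may hold more compounds than are shown below. What is called first, only, known or untested is meant among the compounds shown, and "the series" means these compounds.

Measured in a functional assay on HCT-116 cells (Homo sapiens), read by MTT assay, with a stated time of 72 h; on this read-out lower numbers stand for stronger inhibition and higher numbers for weaker inhibition:
- compound 1 `COc1ncnc2c1c(-c1cc3ccccc3o1)cn2[C@@H]1O[C@H](CO)[C@@H](O)[C@H]1O`: 14500 nM
- compound 2 `O=c1[nH]cnc2c1c(-c1cc3ccccc3o1)cn2[C@@H]1O[C@H](CO)[C@@H](O)[C@H]1O`: > 20000 nM (a limit)
- compound 3 `Nc1nc(N)c2c(-c3ccco3)cn([C@@H]3O[C@H](CO)[C@@H](O)[C@H]3O)c2n1`: > 20000 nM (a limit)

Compound 3 stands at > 20000 nM, which is a limit and not a number; this is the limit of > 20000 nM in this assay, at which 2 of the 3 values shown sit. Compound 4 `Nc1nc(N)c2c(-c3cc4ccccc4o3)cn([C@@H]3O[C@H](CO)[C@@H](O)[C@H]3O)c2n1` keeps the core of compound 3 and carries 1-benzofuran-2-yl in place of furan-2-yl on an aromatic carbon.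

Among the measured compounds shown here, no measured pair isolates this change, and the other two compounds have a different core. Both carry the incoming group. Compound 1 gives 14500 nM, a number. Compound 2 gives > 20000 nM, again a limit. On that basis, only a modest shift towards stronger inhibition in this assay is expected, and the result may remain a limit. The expected change is an at least 1.3-fold lower number from compound 3 to compound 4 (0.12 log units; that floor lies within the scatter). Compound 4 is estimated at 15000 nM, with an expected range of 4000 nM to 30000 nM.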

Compound 4, half-maximal inhibitory concentration: 14000 nM
For compound 4 the middle estimate is 1.1-fold (0.03 log units) above the measured one; the range from low to high includes it.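

In this assay, the diamino core gives a number rather than a limit once it carries 1-benzofuran-2-yl: compound 4 gives 14000 nM. Compound 3, with furan-2-yl on the same aromatic carbon, remains a limit at > 20000 nM. The step is an at least 1.4-fold lower number from compound 3 to compound 4 (0.15 log units; that floor lies within the scatter), and only a floor can be read because compound 3 sits at the limit of the assay: the limit of > 20000 nM in this assay, at which 2 of the 4 values shown sit.

As far as these compounds go, the true size of this step stays open, and with it whether the change exceeds the scatter at all. Also open, from the compounds shown here alone, is how this aromatic carbon responds to other groups, such as phenyl, a simple amine or a carboxylic acid, in this assay.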